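Swapping 5-methylfuran-2-yl for 4-chlorophenyl in compound 2

The source may hold more compounds than are shown below. What is called first, only, known or untested is meant among the compounds shown, and "the series" means these compounds.

In a functional assay on HCT-15 cells (Homo sapiens) for cytotoxicity, read by ELISA, with a stated time of 4 days (on this read-out lower numbers stand for stronger inhibition and higher numbers for weaker inhibition), compound 1 (`Cc1ccsc1-c1cc(-c2ccoc2)cc(-c2ccc(Cl)cc2)n1`) gives 2990 nM, while compound 2 (`Cc1ccc(-c2cc(-c3ccoc3)cc(-c3ccc(Cl)s3)n2)o1`) gives 790 nM, which lies on the lower side of compound 1 and beyond the scatter. Compound 3 (`Cc1ccc(-c2cc(-c3ccoc3)cc(-c3ccc(Cl)s3)n2)cc1`) gives 1170 nM, within the scatter of compound 2. Compound 4 (`Clc1ccc(-c2cc(-c3ccoc3)cc(-c3ccc(Cl)s3)n2)cc1`), not yet measured, has 4-chlorophenyl in place of 5-methylfuran-2-yl on an aromatic carbon, next to the ring nitrogen of compound 2: 4-chlorophenyl in place of 5-methylfuran-2-yl on an aromatic carbon. Among the measured compounds shown here, the only measured step that bears on this change replaces the same group with 4-methylphenyl, and it is a 1.5-fold higher number from compound 2 to compound 3 (0.17 log units; within the scatter). For the measured compounds named here, compound 1 offers no measured step of this kind. Given that small step to compound 3, no shift beyond the scatter is expected in this assay, though the number may drift slightly upward. The expected change is a 1.4-fold higher number from compound 2 to compound 4 (0.14 log units; within the scatter). For compound 4 the estimated value is 1100 nM, with an expected range from 500 nM to 2400 nM.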

Compound 4, half-maximal inhibitory concentration: 640 nM
Beside the measured number, compound 4's estimate is 1.7-fold (0.24 log units) above it, within the range that was stated.
By their numbers in this assay, from the lowest: compounds 4, 2 and 3 (each within the scatter of the next); then compound 1.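

In this assay, the place next to the ring nitrogen now accepts a third aromatic ring without a shift beyond the scatter: the exchange of 5-methylfuran-2-yl for 4-chlorophenyl gives a 1.2-fold lower number from compound 2 to compound 4 (0.09 log units; within the scatter), and chloro in place of methyl on that ring gives a 1.8-fold lower number from compound 3 to compound 4 (0.26 log units; within the scatter). Among the compounds shown here, the only new step beyond the scatter lies elsewhere on the core, with 5-chlorothiophen-2-yl in place of 3-methylthiophen-2-yl giving a 4.7-fold lower number from compound 1 to compound 4 (0.67 log units; beyond the scatter), a modest change beside the near-silent swaps at the first place. No measurement is available that accounts for either outcome.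

From the compounds shown here alone, all three groups seen at the place next to the ring nitrogen are aromatic rings, so it remains open how an amine, a carboxylic acid or a longer chain would read there. Going by these compounds, it is also open whether the thiophene step would keep its size with 5-methylfuran-2-yl or 4-methylphenyl in that place.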